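This account rests on a few compounds, and the source may have more. Where it says the series, first, only, none or still open, it means among the compounds named here.

Measured in a functional assay (Saphenous vein) with Canis familiaris (Canis lupus familiaris) as the target; on this read-out higher numbers stand for higher potency (the scale is a negative logarithm) and lower numbers for lower potency:
- compound 1 `COc1ccc(C(=O)Nc2ccc(-c3ccncc3)cc2)cc1CCCN(C)C`: 7.8
- compound 2 `COc1ccc(C(=O)Nc2ccc(-c3ccc(-c4noc(C)n4)cc3C)cc2)cc1N1CCN(C)CC1`: 8.2

Of these two compounds, compound 1 holds the lower position at 7.8. The nearest number belongs to compound 2 at 8.2, and that gap lies beyond the usual scatter of repeated measurements.

The next compound to be tested is compound 3 `COc1ccc(C(=O)Nc2ccc(-c3ccc(C(=O)O)cc3C)cc2)cc1CCCN(C)C`, which has no value yet. It keeps the core of compound 1 and differs from it at one place: 4-carboxy-2-methylphenyl in place of pyridin-4-yl on an aromatic carbon. In words, 4-carboxy-2-methylphenyl stands in place of pyridin-4-yl on an aromatic carbon, para to a large group.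

Going by the values given here, no pair of measured compounds differs in one place only, so the data show no direct precedent for this exchange, and the expectation is correspondingly loose. In this assay a modest fall in potency is expected rather than a gain. The estimated change is a number 0.40 log units lower from compound 1 to compound 3 (beyond the scatter). The estimate for compound 3 is 7.4, with an expected range from 6.6 to 8.1.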

Compound 3, negative logarithm of the antagonist equilibrium constant: 8.7
Estimate against measurement, compound 3: 1.30 log units below; the measured number lies above the stated range.
By their numbers in this assay, from the lowest: compound 1; then compound 2; then compound 3.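

In this assay, the exchange of pyridin-4-yl for 4-carboxy-2-methylphenyl gives a number 0.90 log units higher from compound 1 to compound 3 (beyond the scatter) and places compound 3 highest of the three compounds. This shows that the aromatic carbon para to a large group accepts a larger group, with a carbon-only aromatic ring, a double bond outside the ring and a hydrogen-bond donor, without any loss of potency, and that giving up the ring nitrogen of pyridin-4-yl does not cost potency in this context. The measurements at hand give no information on why the number rises.

Going by these compounds alone, the single step changes several things at once, so it remains open whether the gain belongs to the carboxylic acid, to the methyl or to the carbon-only ring itself. A phenyl carrying only the methyl, a phenyl carrying only the carboxylic acid, or a methyl ester or primary amide in place of the acid would be needed to separate these contributions, and none of them is among the compounds shown.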